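Acetyl to Sulfamoyl: One Change, One Expected Shift

The source may hold more compounds than are shown below. What is called first, only, known or untested is meant among the compounds shown, and "the series" means these compounds.

Of the compounds shown here, three built on a shared core have been tested in an assay on RBL-1 cells with Polyunsaturated fatty acid 5-lipoxygenase (Rattus norvegicus) as the target; on this read-out lower numbers stand for stronger inhibition and higher numbers for weaker inhibition. Compound 1 `CC(C)(C)c1ccc2ccccc2c1O` gives 180 nM in this assay. Compound 2 `Cc1cc(C)c2ccc(Cc3ccccc3)c(O)c2c1` gives 62 nM in this assay. Compound 3 `CC(=O)c1cc(Cc2ccccc2)c(O)c2ccccc12` gives 510 nM in this assay, the highest of the three numbers and therefore the weakest inhibition shown; the gap to compound 1 and the larger gap to compound 2 both lie beyond the usual scatter of repeated measurements.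

The next compound, compound 4 `NS(=O)(=O)c1cc(Cc2ccccc2)c(O)c2ccccc12`, differs from compound 3 in a single spot: sulfamoyl in place of acetyl on an aromatic carbon. For the measured compounds named here, no step of this kind has been measured among the compounds so far, so there is nothing to say how the exchange of one small group for another at this spot affects inhibition, and the expectation rests only on compound 3 itself.

Going by the values given here, with no guiding precedent, the expected step from compound 3 to compound 4 is a 1.2-fold higher number from compound 3 to compound 4 (0.07 log units; within the scatter), a shift that may not rise above the scatter. Compound 4 is therefore estimated at 600 nM in this assay, with a plausible range from 150 nM to 2500 nM.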

Compound 4, half-maximal inhibitory concentration: 9400 nM
The estimate for compound 4 lay 16-fold (1.19 log units) below the measured number, outside the stated range (above it).
By their numbers in this assay, from the lowest: compound 2; then compound 1; then compound 3; then compound 4.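

This position, on an aromatic carbon para to a hydroxy group, proves sensitive to the group it carries: in this assay, sulfamoyl in place of acetyl gives an 18-fold higher number from compound 3 to compound 4 (1.27 log units; beyond the scatter), so inhibition falls sharply with this one exchange. For the compounds shown here, the earlier compounds offered no measured exchange at this spot, so this is the first sign that a modest swap of one small group for another here can matter a great deal. Sulfamoyl, unlike acetyl, carries a hydrogen-bond donor and has nitrogen and sulfur in its make-up, but nothing measured on these compounds shows which of these differences, if any, lies behind the step.

Still open, as far as these compounds go, is how acetyl itself ranks at this position, and a plain hydrogen, an amine, a carboxylic acid or a methyl sulfone there would show whether sulfamoyl is unusually poor or acetyl unusually good. Also open, from the compounds shown here alone, is whether the step would keep its size if a longer chain took the place of the benzyl group.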